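A Pyridine Swap on the Amine Arm

This account rests on a few compounds, and the source may have more. Where it says the series, first, only, none or still open, it means among the compounds named here.

Among the compounds with values here, compound 2 `O=C(NC1CCN(Cc2ccccc2Cl)CC1)c1ccc2ccccc2c1` is one of three compounds measured here on a shared core. In an assay on isolated protein for displacement of a labelled ligand from D(4) dopamine receptor (Homo sapiens), tested at 1 uM (on this read-out lower numbers stand for less inhibition and higher numbers for more inhibition at the one concentration tested (going by the name of the read-out)), compound 2 gives 48%, the highest of the three numbers. Compound 1 `O=C(NC1CCN(Cc2ccc([N+](=O)[O-])cc2)CC1)c1cccc2ccccc12` gives 42%, which lies within the scatter of compound 2, so the two cannot be ranked against each other. Compound 3 `O=C(NC1CCN(Cc2c(F)c(F)c(F)c(F)c2F)CC1)c1ccc2ccccc2c1` gives 0%, a gap from compound 2 that lies beyond the scatter. Compound 4 `O=C(NC1CCN(Cc2ccncc2)CC1)c1ccc2ccccc2c1` has not yet been measured in this assay; it differs from compound 2 in one place: pyridin-4-yl in place of 2-chlorophenyl on a saturated chain carbon bound to an amine nitrogen in a ring. Within the data shown here, no measured pair shows this kind of change, so its effect is unknown from the data. A moderate decrease is expected, a number 23 percentage points lower from compound 2 to compound 4 (beyond the scatter). Compound 4 is therefore estimated at 25%, with a range from 5% to 50%.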

Compound 4, a percentage reported as inhibition, at one concentration (the size of the read-out at that concentration, not a potency): 32%
For compound 4 the middle estimate is 7 percentage points below the measured one, and the stated range covers the measured number.
By their numbers in this assay, from the lowest: compound 3; then compounds 4, 1 and 2 (each within the scatter of the next, the first and the last beyond it).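

In this assay, within the data shown here, pyridin-4-yl in place of 2-chlorophenyl gives a number 16 percentage points lower from compound 2 to compound 4 (beyond the scatter) and so provides the first measured step at this position. This shows that the number responds to exchanging one six-membered aromatic ring for another on the saturated chain carbon, even though the swap removes only one heavy atom and adds one hydrogen-bond acceptor. Nothing available here accounts for the size or direction of this step.

Going by these compounds, how a plain phenyl group would read at this place remains open. So does whether the lower number goes with losing the chlorine or with gaining the ring nitrogen.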